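A few compounds are considered here, and "the series" means these few. Any claim that something is new, unique, unknown or untested is made for them only; others in the source may bear on it.

Of the compounds shown here, three built on a shared core have been tested in a functional assay on MCF7 cells (Homo sapiens) for cytotoxicity, read by colorimetric assay; a higher number here means a weaker inhibitor, a lower number a stronger inhibitor. Compound 1 `COc1ccc2c(c1)O[C@H](c1ccc(O)c(OC)c1)CC2` gives 88400 nM. Compound 2 `COc1cc2c(cc1O)CC[C@@H](c1ccc(O)c(O)c1)O2` gives 110000 nM, the highest of the three numbers; its gap to compound 1 lies within the scatter, so the two cannot be told apart, whereas compound 3 `COc1cc(OC)c2c(c1)O[C@H](c1ccc(O)c(O)c1)CC2` gives 49200 nM, a number lower than that of compound 2 by more than the scatter.

Compound 4 `COc1cc2c(cc1OC)O[C@H](c1ccc(O)c(O)c1)CC2` has not yet been measured in this assay. It differs from compound 2 in one place: methyl in place of hydrogen on an oxygen on an aromatic ring. For the measured compounds named here, no pair among the measured compounds differs in just one place, so nothing measured here shows what such a change does on its own. A small step is expected, in either direction or none beyond the scatter. On that basis compound 4 is expected to give about 85000 nM, within a range from 35000 nM to 200000 nM. This estimate means a step of a 1.3-fold lower number from compound 2 to compound 4 (0.11 log units; within the scatter) that is expected to stay within the scatter.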

Compound 4, half-maximal inhibitory concentration: 75000 nM
Compound 4: middle estimate off by 1.1-fold (0.05 log units), on the high side, and the stated range covers the measured number.
By their numbers in this assay, from the lowest: compounds 3, 4, 1 and 2 (each within the scatter of the next, the first and the last beyond it).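

For the compounds shown here, the new pair is the first here to differ in just one place, so the change from hydroxy to methoxy can now be read on its own: in this assay the step is a 1.5-fold lower number from compound 2 to compound 4 (0.17 log units; within the scatter). At this oxygen on an aromatic ring, methyl can therefore take the place of hydrogen with no shift that can be told apart from the ordinary spread of repeated measurements. Nothing available here bears on why this change has so small an effect.

Going by these compounds, it remains open whether a larger group on the same oxygen, such as a longer chain ending in an amine or a carboxylic acid, would move the number beyond the scatter. On these data alone, it is also open whether the same change at either of the two hydroxy groups still present in compound 4 would prove equally small.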